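Methyl to Hydrogen on the Aryl Ether Oxygen

The source may report more compounds than this note shows. Statements on the series, on what has been measured and on what is new or still open speak of the compounds shown alone.

Compound 1: `O=C(Nc1cccc(-n2cc(-c3ccncc3)c(-c3ccc(Cl)c(O)c3)n2)c1)Nc1cccc(C(F)(F)F)c1`; in a functional assay on SK-MEL-28 cells (Homo sapiens) for inhibition, read by sulforhodamine B assay, with a stated time of 48 h (a higher number here means a weaker inhibitor of growth, a lower number a stronger inhibitor of growth), compound 1 reaches only the assay limit, reported as > 32500 nM.
Compound 2: `COc1cc(-c2nn(-c3cccc(NC(=O)Nc4cc(C(F)(F)F)cc(C(F)(F)F)c4)c3)cc2-c2ccncc2)ccc1Cl`; compound 2 gives 1700 nM.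
Compound 3: `COc1cc(-c2nn(-c3cccc(NC(=O)Nc4cccc(C(F)(F)F)c4)c3)cc2-c2ccncc2)ccc1Cl`; compound 3 gives 3350 nM.

Compound 2 holds the lowest of the two numbers, with compound 3 nearest by a 2.0-fold higher number from compound 2 to compound 3 (0.29 log units; within the scatter), a gap within the scatter. Compound 4, `O=C(Nc1cccc(-n2cc(-c3ccncc3)c(-c3ccc(Cl)c(O)c3)n2)c1)Nc1cc(C(F)(F)F)cc(C(F)(F)F)c1`, differs from compound 2 by hydrogen in place of methyl on an oxygen on an aromatic ring. For the measured compounds named here, the only measured step on this change runs the opposite way, an at least 9.7-fold lower number from compound 1 to compound 3 (0.98 log units; beyond the scatter), and compound 1 there sits at the limit of > 32500 nM in this assay, at which 1 of the 3 values shown sits. Reversing it, the number for compound 4 is expected to climb well beyond the scatter, by about a 15-fold higher number from compound 2 to compound 4 (1.17 log units; beyond the scatter). Compound 4 is therefore estimated at 25000 nM, within 8000 nM to 80000 nM, and may itself be returned as a limit.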

Compound 4, concentration for total growth inhibition: 1570 nM
Estimate against measurement, compound 4: 16-fold (1.20 log units) above; measured number below the stated range.
By their numbers in this assay, from the lowest: compounds 4, 2 and 3 (each within the scatter of the next, the first and the last beyond it). At a limit, above all of these: compound 1.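

In this assay, methoxy to hydroxy on the core of compound 2 gives a 1.1-fold lower number from compound 2 to compound 4 (0.03 log units; within the scatter), so the hydroxy form keeps a measurable number on this core. Starting from compound 1, whose value is a limit, trifluoromethyl in place of hydrogen gives an at least 20-fold lower number from compound 1 to compound 4 (1.31 log units; beyond the scatter). The outcome of methoxy to hydroxy therefore depends on the core that carries it: the same change on two cores in this assay, an at least 9.7-fold lower number (0.98 log units; beyond the scatter) from compound 1 to compound 3 and a 1.1-fold higher number (0.03 log units; within the scatter) from compound 4 to compound 2, at least 10-fold (1.02 log units) apart, beyond the scatter of two such steps.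

The compounds shown leave open whether an ethoxy group or an amine in the same place would follow compound 2 or compound 1.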